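This account rests on a few compounds, and the source may have more. Where it says the series, first, only, none or still open, it means among the compounds named here.

Working notes on the series. The shared core of compound 1 `FC(F)(F)c1ccccc1Nc1nc(-c2ccncc2)cs1` is held across the set; compound 3 `Brc1cccc(Nc2nc(-c3ccncc3)cs2)c1` carries a bromine on the same ring, and compound 2 `Cc1cccc(Nc2nc(-c3ccnc(OCCCN(C)C)c3)cs2)c1` carries a methyl there together with a side chain on the pyridine. In a functional assay on RCC4 cells (Homo sapiens) for inhibition, read by XTT assay, with a stated time of 4 days (a lower number here means a stronger inhibitor, a higher number a weaker inhibitor), compound 1 gives 40700 nM, and compound 3 gives 40700 nM, level with compound 1 at the digits shown and within the scatter. Compound 2 is measured more than once in this assay, giving 6000 nM; 6030 nM (2 entries) (the several entries of compound 2 in this assay, 6000 nM; 6030 nM (2 entries)), and its repeat entries agree closely; no single change links compound 2 to compound 1, so only its numbers are noted.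

The next compound, compound 4 `O=[N+]([O-])c1ccccc1Nc1nc(-c2ccncc2)cs1`, differs from compound 1 in one place: nitro in place of trifluoromethyl on an aromatic carbon. Among the measured compounds shown here, no measured pair shows this exchange, and the two measured substituents on that ring (compound 1, compound 3) give no separation beyond the scatter. The expected step from compound 1 to compound 4 is therefore a 1.2-fold lower number from compound 1 to compound 4 (0.07 log units; within the scatter), with no direction assumed beyond the scatter. Compound 4 is estimated at 35000 nM in this assay, within the range 9000 nM to 120000 nM.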

Compound 4, half-maximal inhibitory concentration: 40700 nM
Estimate against measurement, compound 4: 1.2-fold (0.07 log units) below; measured number inside the range.
By their numbers in this assay, from the lowest: compounds 1, 3 and 4 (each within the scatter of the next).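

Among the compounds shown here, the exchange of trifluoromethyl for nitro on an aromatic carbon ortho to a large group is the first single change read at this position, and in this assay it gives no change at the digits printed from compound 1 to compound 4 (within the scatter). The entering nitro brings 2 hydrogen-bond acceptors where the leaving trifluoromethyl has 0, and it has one heavy atom fewer, yet the number does not separate from that of compound 1. At this position, then, these two groups are not told apart by this read-out.

From the compounds shown here alone, whether an amine or a carboxylic acid on the same aromatic carbon would move the number remains open. So does the contribution of the side chain in compound 2, which no single change links to compound 1.

No measurement at hand bears on why this exchange leaves the number where it is.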